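Acetylpyrazole Swap on the Benzamide Ring

This account rests on a few compounds, and the source may have more. Where it says the series, first, only, none or still open, it means among the compounds named here.

Measured compounds:
compound 1 `CNC(=O)N1CCCc2ccc(NC(=O)c3cccc(-c4ccn(C(C)=O)n4)c3)cc21` — 87.6%
compound 2 `CNC(=O)N1CCCc2ccc(NC(=O)c3ccc(-c4ccn(C)n4)cc3)cc21` — 97%

In a functional assay on MV4-11 cells (Homo sapiens) for antiproliferative activity, with a stated time of 6 days, tested at 6.25 uM (a lower number here means a weaker effect, a higher number a stronger effect of the compound at the concentration tested), compound 2 gives 97%. Compound 1 gives 87.6% in this assay. Of the two numbers, that of compound 2 is nominally the upper one, but the gap to compound 1 lies within the usual scatter, so the two compounds cannot be told apart on these data.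

Compound 3 `CNC(=O)N1CCCc2ccc(NC(=O)c3ccc(-c4cnn(C(C)=O)c4)cc3)cc21` has not yet been measured. It differs from compound 2 in one place: 1-acetyl-1H-pyrazol-4-yl in place of 1-methyl-1H-pyrazol-3-yl on an aromatic carbon. For the measured compounds named here, no step between two measured compounds isolates this change, so there is no measured precedent to lean on. Since compound 1, which also carries an acetyl on its pyrazole, sits within the scatter of compound 2, no step beyond the scatter is expected. The step from compound 2 to compound 3 is estimated as a number 7 percentage points lower from compound 2 to compound 3 (within the scatter). Compound 3 is therefore expected to give 90%, within a range of 76% to 99%.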

Compound 3, a percentage reported as inhibition, at one concentration (the size of the read-out at that concentration, not a potency): 83.8%
Beside the measured number, compound 3's estimate is 6.2 percentage points above it; the range from low to high includes it.
By their numbers in this assay, from the lowest: compounds 3, 1 and 2 (each within the scatter of the next, the first and the last beyond it).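

In this assay, putting 1-acetyl-1H-pyrazol-4-yl in place of 1-methyl-1H-pyrazol-3-yl on an aromatic carbon para to a large group gives a number 13.2 percentage points lower from compound 2 to compound 3 (beyond the scatter), so this position does respond to the choice of pyrazole group, although compound 3 still gives 83.8% at the single concentration tested. The swap changes both the group on the pyrazole and the pyrazole's point of attachment, so the step cannot be assigned to either change alone. Nothing available explains the step.

The compounds shown leave open how much of the step belongs to the acetyl group and how much to the attachment point, a question that 1-methyl-1H-pyrazol-4-yl at the same place would separate. They also leave open how a pyrazole carrying an aminoethyl or carboxymethyl chain would behave here.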